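Trimming One Methoxy From a Trimethoxyphenyl-Pyrazole Enone

The source may report more compounds than this note shows. Statements on the series, on what has been measured and on what is new or still open speak of the compounds shown alone.

Compound 1, `COc1cc(-c2cc(/C=C/C(=O)c3ccc(N)cc3)[nH]n2)cc(OC)c1OC`, gives 85% in a functional assay on T47D cells (Homo sapiens) for cytotoxicity, read by sulforhodamine B assay, with a stated time of 48 h, tested at 0.1 uM; a lower number here means a stronger effect, a higher number a weaker effect of the compound at the concentration tested.
Compound 2, `COc1ccc(C(=O)/C=C/c2cc(-c3cc(OC)c(OC)c(OC)c3)n[nH]2)cc1OC`, gives 98% in this assay.

Compound 2 stands as the higher of the two numbers shown, the weaker effect at the concentration tested; its nearest neighbour is compound 1, and the step of a number 13 percentage points higher from compound 1 to compound 2 (beyond the scatter) lies beyond the scatter. Compound 3, `COc1ccc(C(=O)/C=C/c2cc(-c3cc(OC)c(OC)c(OC)c3)n[nH]2)cc1`, has not been measured. It differs from compound 2 in one place: hydrogen in place of methoxy on an aromatic carbon, the 3,4-dimethoxyphenyl on the carbonyl carbon becoming 4-methoxyphenyl.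

Among the compounds with values here, the only measured step, from compound 1 to compound 2, exchanges the whole aryl group on the carbonyl carbon rather than a single methoxy, so it bears on the present change only loosely; it shows that this part of the molecule can move the read-out by a modest amount. With both measured numbers at the weak end of the scale, the expected step of a number 4 percentage points lower from compound 2 to compound 3 (within the scatter) is small, likely within the scatter. Compound 3 is therefore estimated at 94%, within a range from 80% to 103%.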

Compound 3, a percentage reported as activity, at one concentration (the size of the read-out at that concentration, not a potency): 93%
Compound 3: middle estimate off by 1 percentage points, on the high side; the range from low to high includes it.
By their numbers in this assay, from the lowest: compounds 1, 3 and 2 (each within the scatter of the next, the first and the last beyond it).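

Removing one methoxy, so that the 3,4-dimethoxyphenyl becomes 4-methoxyphenyl, gives a number 5 percentage points lower from compound 2 to compound 3 (within the scatter) in this assay, so at this aromatic carbon, ortho to a methoxy group, hydrogen and methoxy cannot be told apart in this read-out. The exchange of amino for methoxy on an aromatic carbon, the other single change now available, gives a number 8 percentage points higher from compound 1 to compound 3 (within the scatter), which means that the earlier step, a number 13 percentage points higher from compound 1 to compound 2 (beyond the scatter), divides into two smaller steps that each stay within the scatter, and neither change alone can be said to move the number. Nothing available bears on why the read-out behaves this way.

All three compounds sit at the weak end of the scale at a single concentration, so these numbers leave open whether the two methoxy patterns would differ under conditions where the compounds have a stronger effect. Also open, going by these compounds, is whether a hydroxy group, a longer alkoxy chain or an amine at this aromatic carbon would move the read-out beyond the scatter, or would leave it as little changed as hydrogen does.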